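Swapping the ring on the sulfonyl sulfur of compound 3

A few compounds are considered here, and "the series" means these few. Any claim that something is new, unique, unknown or untested is made for them only; others in the source may bear on it.

Three sulfonylureas have been tested in a functional assay on the whole organism (6C3HED cells, Mus musculus) for inhibition, at a dose of 150 mg/kg by the oral route; on this read-out lower numbers stand for less inhibition and higher numbers for more inhibition at the one dose given (going by the name of the read-out). Compound 1 `Cc1ccc(S(=O)(=O)NC(=O)Nc2ccc(Cl)c(Cl)c2)s1` gives 24%, compound 2 `CCc1ccc(S(=O)(=O)NC(=O)Nc2ccc(Cl)cc2)s1` gives 57%, and compound 3 `CCc1ccc(S(=O)(=O)NC(=O)Nc2ccc(Cl)cc2)o1` gives 57%. Compound 3 thus stands level with compound 2 within the scatter, and the two together are the highest of the three numbers, while compound 1 sits clearly lower, beyond the scatter. Within the data shown here, the one single-site step measured so far, no change at the digits printed from compound 2 to compound 3 (within the scatter), shows that exchanging the ring heteroatom of the ring on the sulfonyl sulfur made no difference within the scatter.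

Compound 4 `O=C(Nc1ccc(Cl)cc1)NS(=O)(=O)c1cc(Br)c(Br)s1` differs from compound 3 at that same place: 4,5-dibromothiophen-2-yl in place of 5-ethylfuran-2-yl on a sulfonyl sulfur. Among the measured compounds shown here, no measured step covers this exchange of both ring heteroatom and ring substituents, and compound 1 differs from the others in two places, so its value cannot be read as a single step. For the measured compounds named here, the only guidance is that the one measured change of the ring on the sulfonyl sulfur, no change at the digits printed from compound 2 to compound 3 (within the scatter), left the number level within the scatter, so compound 4 is expected near compound 3, with wide uncertainty, giving a step of a number 12 percentage points lower from compound 3 to compound 4 (beyond the scatter). The estimate for compound 4 in this assay is 45%, with a range from 15% to 75%.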

Compound 4, a percentage reported as inhibition, in the whole organism at one dose (the size of the read-out at that dose, not a potency): 25%
The estimate for compound 4 lay 20 percentage points above the measured number, and the stated range covers the measured number.
By their numbers in this assay, from the lowest: compounds 1 and 4 (each within the scatter of the next); then compounds 2 and 3 (each within the scatter of the next).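

This position is not indifferent in this assay: 4,5-dibromothiophen-2-yl in place of 5-ethylfuran-2-yl gives a large fall (a number 32 percentage points lower from compound 3 to compound 4 (beyond the scatter)), and in place of 5-ethylthiophen-2-yl it gives the same fall (a number 32 percentage points lower from compound 2 to compound 4 (beyond the scatter)). The level result between the two ethyl rings (no change at the digits printed from compound 2 to compound 3 (within the scatter)) therefore does not extend to every ring here, and since compound 2 and compound 4 both carry a thiophene, their difference lies in what that ring carries, not in the ring itself. The counts do not separate the groups either, as both have 7 heavy atoms, and nothing measured here explains the fall.

As far as these compounds go, it remains open whether one bromine alone would give the same fall, or whether both are needed. From the compounds shown here alone, how a ring carrying an amine or a longer alkyl chain would behave also remains open.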